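Moving Away from the Weaker Aryl Groups

A few compounds are considered here, and "the series" means these few. Any claim that something is new, unique, unknown or untested is made for them only; others in the source may bear on it.

In a functional assay on KBVIN cells (Homo sapiens) for antiproliferative activity, read by sulforhodamine B assay, with a stated time of 3 days (a lower number here means that less compound is needed, a higher number that more compound is needed for the effect), compound 3 (`CCC1=C(O)c2c(oc(-c3ccccc3OC)cc2=O)C(CC)(CC)C1=O`) gives a value of 3.26 uM and shares its level with compound 2 (`CCC1=C(O)c2c(oc(-c3ccccc3C)cc2=O)C(CC)(CC)C1=O`) at 2.41 uM, since a 1.4-fold higher number from compound 2 to compound 3 (0.13 log units; within the scatter) is within the scatter. Both lie far from compound 1 (`CCC1=C(O)c2c(oc(-c3ccc(CC)cc3)cc2=O)C(CC)(CC)C1=O`), which gives 0.07 uM in this assay. The next compound is compound 4 (`CCC1=C(O)c2c(oc(-c3ccc(C)c(C)c3)cc2=O)C(CC)(CC)C1=O`), with 3,4-dimethylphenyl in place of 2-methoxyphenyl on an aromatic carbon. Among the compounds with values here, two measured steps bear most directly on this change, a 34-fold higher number from compound 1 to compound 2 (1.54 log units; beyond the scatter) and a 47-fold higher number from compound 1 to compound 3 (1.67 log units; beyond the scatter), and both are large and beyond the scatter. The aryl group of compound 4 carries only alkyl substituents, as does that of compound 1, and it appears closer to that group than to the aryl groups of compound 2 and compound 3. Part of that large gap should therefore be recovered, though probably not all of it, as no measured compound carries 3,4-dimethylphenyl. A large step toward a lower number is expected in this assay, estimated as a 13-fold lower number from compound 3 to compound 4 (1.12 log units; beyond the scatter) here. Compound 4 is expected at about 0.25 uM in this assay, with an estimated range from 0.06 uM to 1 uM as the likely span.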

Compound 4, concentration for half-maximal effect: 0.71 uM
Compound 4: middle estimate off by 2.8-fold (0.45 log units), on the low side; low and high end bracket the measured number.
By their numbers in this assay, from the lowest: compound 1; then compound 4; then compounds 2 and 3 (each within the scatter of the next).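

In this assay, the aromatic carbon next to the ring oxygen proves to hold a third level of activity rather than only the two seen before: 3,4-dimethylphenyl gives a 4.6-fold lower number from compound 3 to compound 4 (0.66 log units; beyond the scatter) and, against the 2-methylphenyl group, a 3.4-fold lower number from compound 2 to compound 4 (0.53 log units; beyond the scatter) while still leaving a 10-fold higher number from compound 1 to compound 4 (1.01 log units; beyond the scatter) on the other side. The aryl groups of compound 1, compound 2 and compound 4 all carry only alkyl substituents yet stand at three separate levels, so the mere absence of the methoxy group of compound 3 does not account for the level at this position, and compound 2 goes directly against any such reading. Nothing shown here explains why these aryl groups differ as they do.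

The compounds leave open whether the low number of compound 1 depends on the ethyl group itself, as no aryl group here carries a single methyl or a propyl chain in its place. They also leave open how a dimethylamino group or a carboxylic acid on this aryl ring would fare.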